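Para substituent swap on the diester series: chloro for methoxy

This account rests on a few compounds, and the source may have more. Where it says the series, first, only, none or still open, it means among the compounds named here.

Within the data shown here, in a functional assay on the whole organism (Abdomen, strain Swiss albino) with Mus musculus as the target, with stated times of 10 min and 5 min, at a dose of 30 mg/kg by the oral route (on this read-out higher numbers stand for a stronger effect at the one dose given and lower numbers for a weaker effect), compound 3 `CCOC(=O)c1onc(-c2cn(-c3ccccc3)nc2-c2ccc(OC)cc2)c1C(=O)OCC` gives 57.7%, the largest of the three numbers so far. Compound 2 `CCOC(=O)c1onc(-c2cn(-c3ccccc3)nc2-c2ccc(Br)cc2)c1C(=O)OCC` gives 56.9%, and the step of a number 0.8 percentage points higher from compound 2 to compound 3 (within the scatter) shows that the bromo-to-methoxy exchange on that aromatic carbon did not move the read-out beyond the scatter. Compound 1 `O=C1C2ON=C(c3cn(-c4ccccc4)nc3-c3ccccc3)C2C(=O)N1c1ccccc1`, built on a different core, gives 47.4%, which lies beyond the scatter below compound 3.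

Compound 4 `CCOC(=O)c1onc(-c2cn(-c3ccccc3)nc2-c2ccc(Cl)cc2)c1C(=O)OCC` differs from compound 3 by chloro in place of methoxy on an aromatic carbon. Among the measured compounds shown here, the only step that bears on this position is the one from compound 2 to compound 3, which stayed within the scatter; no measured step compares chloro directly with either bromo or methoxy. On that basis no step beyond the scatter is expected in this assay, and the step of a number 1.7 percentage points lower from compound 3 to compound 4 (within the scatter) is estimated to be small in either direction. Compound 4 is therefore expected to give about 56% in this assay, with a range from 46% to 66%.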

Compound 4, a percentage reported as activity, at one dose (the size of the read-out at that dose, not a potency): 55.3%
Compound 4: the middle estimate sits 0.7 percentage points above what was measured, within the range that was stated.
By their numbers in this assay, from the lowest: compounds 1, 4, 2 and 3 (each within the scatter of the next, the first and the last beyond it).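

In this assay the step of a number 2.4 percentage points lower from compound 3 to compound 4 (within the scatter) and the step of a number 1.6 percentage points lower from compound 2 to compound 4 (within the scatter) both stay within the scatter, so chloro now joins bromo and methoxy on this aromatic carbon without a step beyond the scatter between any two of them. Until now only the exchange of bromo and methoxy had been read here; the 4-chlorophenyl, 4-bromophenyl and 4-methoxyphenyl diesters cannot be told apart at the single dose given. No supporting measurement bears on why these exchanges leave the read-out within the scatter.

Still open, from the compounds shown here alone, is whether an amine or a carboxylic acid on this aromatic carbon would move the read-out beyond the scatter. Also open, going by these compounds, is whether the three compounds would stay together at other doses, since one dose gives the size of the effect and not a potency.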